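This account rests on a few compounds, and the source may have more. Where it says the series, first, only, none or still open, it means among the compounds named here.

Measured so far in an in vitro assay on Sf21 cells for inhibition of high affinity 3',5'-cyclic-AMP phosphodiesterase 7A (Homo sapiens); on this read-out higher numbers stand for weaker inhibition and lower numbers for stronger inhibition:

Compound 1, `CNc1nc(NC2(C#N)CCCCC2)nc(-n2ccnc2)n1`, gives 1050 nM.
Compound 2, `CNc1nc(C#N)nc(NC2(C#N)CCCCC2)n1`, gives > 1000 nM, which is a limit of the assay and not a number.
Compound 3, `CNc1nc(NC2(C#N)CCCCC2)nc(-n2cnc3ccccc32)n1`, gives > 1000 nM, likewise a limit.

Compound 2 therefore stands at the limit of this assay, and so does compound 3, as the limit of > 1000 nM in this assay, at which 2 of the 3 values shown sit, records. Compound 4, `CNc1nc(NC2(C#N)CCCCC2)nc(C2CC2)n1`, differs from compound 2 by cyclopropyl in place of cyano on an aromatic carbon. Within the data shown here, the only measured step touching compound 2 is a step that the limit leaves unreadable from compound 1 to compound 2, and the limit leaves its size unreadable; no measured step involves a cyclopropyl group. No direction for the change can be read from the data. Compound 4 is expected to remain near the limit, with an estimate of 1500 nM spanning 400 nM to 6000 nM, a step that the limit leaves unreadable from compound 2 to compound 4.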

Compound 4, half-maximal inhibitory concentration: 539 nM
Compound 4: middle estimate off by 2.8-fold (0.44 log units), on the high side; the range from low to high includes it.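

In this assay, cyclopropyl at this position gives a 1.9-fold lower number from compound 1 to compound 4 (0.29 log units; within the scatter), so a three-membered ring of carbon only cannot be told apart from 1H-imidazol-1-yl here. Replacing cyano gives an at least 1.8-fold lower number from compound 2 to compound 4 (0.26 log units; that floor lies within the scatter), which gives this change no direction beyond the scatter. That step is only a floor because the value of compound 2 is a limit: the limit of > 1000 nM in this assay, at which 2 of the 4 values shown sit.

Going by these compounds, whether an amine, a carboxylic acid or a longer chain at this position would move the value beyond the scatter remains open. So does the size of the step for cyano.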